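A few compounds are considered here, and "the series" means these few. Any claim that something is new, unique, unknown or untested is made for them only; others in the source may bear on it.

Compound 1 `O=C(O)[C@@H]1CCCN1C(=O)CN(c1nc(Cl)nc2[nH]cnc12)C1CC1` carries the shared core of the series with a 2-carboxypyrrolidin-1-yl group on the carbonyl carbon of the side chain. For the measured compounds named here, in a functional assay on the whole organism (Tail, strain ICR) with Mus musculus as the target, in the tail flick test, with a stated time of 120 min, at a dose of 25 umol/kg by the oral route (on this read-out higher numbers stand for a stronger effect at the one dose given and lower numbers for a weaker effect), compound 1 gives 23.6%, the lowest of the three numbers measured so far. Compound 2 `O=C(OCc1ccccc1)[C@@H]1CCCN1C(=O)CN(c1nc(Cl)nc2[nH]cnc12)C1CC1` gives 38.4%, and the change a number 14.8 percentage points higher from compound 1 to compound 2 (beyond the scatter) lies beyond the scatter. Compound 3 `C[C@@H](O)[C@H](NC(=O)CN(c1nc(Cl)nc2[nH]cnc12)C1CC1)C(=O)OCc1ccccc1` gives 30.7%, which lies within the scatter of compound 1.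

Compound 4 `O=C(CN(c1nc(Cl)nc2[nH]cnc12)C1CC1)N[C@@H](CO)C(=O)O` has not yet been measured. Compared with compound 1 it shows ((1-carboxy-2-hydroxyethyl)amino in place of 2-carboxypyrrolidin-1-yl on a carbonyl carbon). Going by the values given here, no measured step follows exactly this change. Among the compounds with values here, the closest hint comes from compound 2 and compound 3, where a different amino acid at the same carbonyl carbon gives two values within the scatter of each other; the one step that is beyond the scatter, from compound 1 to compound 2, concerns the benzyl ester and not the amino acid. Compound 4 is therefore expected to stay close to compound 1, with no step beyond the scatter, so that a number 2.6 percentage points lower from compound 1 to compound 4 (within the scatter) is the estimated move. For compound 4 the value in this assay is estimated at 21%, within a range of 9% to 34%.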

Compound 4, a percentage reported as activity, at one dose (the size of the read-out at that dose, not a potency): 39%
Beside the measured number, compound 4's estimate is 18 percentage points below it; measured number above the stated range.
By their numbers in this assay, from the lowest: compounds 1, 3, 2 and 4 (each within the scatter of the next, the first and the last beyond it).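

In this assay, replacing 2-carboxypyrrolidin-1-yl with (1-carboxy-2-hydroxyethyl)amino on the carbonyl carbon gives a number 15.4 percentage points higher from compound 1 to compound 4 (beyond the scatter), so the amino acid at this place can itself move the number while the free carboxylic acid stays in place. Among the earlier compounds, the only step beyond the scatter was the one that put benzyl on the acid oxygen, a number 14.8 percentage points higher from compound 1 to compound 2 (beyond the scatter), which could have suggested that a free acid at this end goes with a low number, but compound 4 carries the free acid and gives 39%, so that reading does not hold across the series. Nothing measured here accounts for the size of this step.

The change removes the ring and adds the hydroxymethyl group in one move, so the compounds shown do not separate the two, and a simple open chain such as (1-carboxyethyl)amino would be needed to tell them apart. Going by these compounds, it also remains open whether a benzyl ester on the group of compound 4, or a methyl ester or primary amide in place of its carboxylic acid, would shift the number further.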